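The source may hold more compounds than are shown below. What is called first, only, known or untested is meant among the compounds shown, and "the series" means these compounds.

Among the compounds with values here, compound 1 `O=C1/C(=C\c2ccncc2)c2ccccc2N1Cc1ccccc1` is one of two compounds so far measured in a functional assay on HL-60 cells (Homo sapiens) for cytotoxicity, read by MTT assay, with a stated time of 72 h, tested at 1 uM; a lower number here means a stronger effect, a higher number a weaker effect of the compound at the concentration tested. In this assay compound 1 gives 85.6%. Compound 2 `O=C1/C(=C\c2cccnc2)c2ccccc2N1Cc1ccccc1` carries a pyridin-3-yl in place of the pyridin-4-yl of compound 1, and in this assay compound 2 gives 93.2%. The step of a number 7.6 percentage points higher from compound 1 to compound 2 (within the scatter) is the only measured one, and it lies within the scatter, so the two compounds cannot be told apart on these numbers; compound 1 merely has the smaller figure of the two.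

Compound 3 `CC(c1ccccc1)N1C(=O)/C(=C\c2ccncc2)c2ccccc21` has not yet been measured. It differs from compound 1 at a different place from where compounds 1 and 2 differ: methyl in place of hydrogen on a saturated chain carbon bound to an amide-type nitrogen in a ring and an aromatic carbon. Within the data shown here, no measured step touches this part of the molecule, and the one step that exists, a number 7.6 percentage points higher from compound 1 to compound 2 (within the scatter), gives no guidance on a methyl added to the saturated chain carbon. Without evidence either way, the expectation for compound 3 is a step of about a number 0.4 percentage points higher from compound 1 to compound 3 (within the scatter), that is, nothing beyond the scatter. Compound 3 is therefore estimated at 86%, with a likely range from 70% to 100%.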

Compound 3, a percentage reported as activity, at one concentration (the size of the read-out at that concentration, not a potency): 49.2%
The estimate for compound 3 lay 36.8 percentage points above the measured number; measured number below the stated range.
By their numbers in this assay, from the lowest: compound 3; then compounds 1 and 2 (each within the scatter of the next).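

Replacing benzyl with 1-phenylethyl adds a single methyl on the saturated chain carbon bound to the amide-type nitrogen in a ring, and in this assay this gives a number 36.4 percentage points lower from compound 1 to compound 3 (beyond the scatter). Within the data shown here, the only earlier step, a number 7.6 percentage points higher from compound 1 to compound 2 (within the scatter), changed the pyridine attachment and stayed within the scatter, so it gave no sign that any part of these molecules could move the read-out this far. This saturated chain carbon is therefore the first position shown to matter, with one added carbon enough to set compound 3 clearly apart from compound 1, although nothing available explains why this small change has so large an effect.

The compounds shown leave open whether the effect depends on the size of the new group, as an ethyl or a longer chain on the same carbon would show, or whether a hydroxyl or an amine there would behave like the methyl. They also leave open whether the same methyl would produce a similar step on the pyridin-3-yl compound 2, and how the step would look at other concentrations.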